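Swapping an ethoxy for a cyclopropylsulfonyl on a Bcl-2 ligand

The source may hold more compounds than are shown below. What is called first, only, known or untested is meant among the compounds shown, and "the series" means these compounds.

Of the compounds shown here, three have been measured in an assay for binding affinity to Apoptosis regulator Bcl-2 (Homo sapiens), read by fluorescence polarization, with a stated time of 2 h; on this read-out lower numbers stand for stronger inhibition and higher numbers for weaker inhibition. Compound 1 `CCOc1cccc(S(=O)(=O)Nc2ccc(N3CCN(c4cccc(-c5c(C(=O)NCCCN6CCN(C)CC6)c(C)n(C)c5-c5ccc(Cl)cc5)c4)CC3)cc2)c1` gives 420 nM in this assay. Compound 2 `Cc1c(C(=O)O)c(-c2cccc(N3CCN(c4ccc(NS(=O)(=O)c5ccc(N[C@H](CCN6CCC(O)CC6)CSc6ccccc6)c(S(=O)(=O)C(F)(F)F)c5)cc4)CC3)c2)c(-c2ccc(Cl)cc2)n1C(C)C` gives 0.8 nM, and compound 3 `Cc1c(C(=O)O)c(-c2cccc(N3CCN(c4ccc(NS(=O)(=O)c5ccc(N[C@H](CCN6CC(O)C6)CSc6ccccc6)c(S(=O)(=O)C(F)(F)F)c5)cc4)CC3)c2)c(-c2ccc(Cl)cc2)n1C` gives 1.7 nM. Among the compounds with values here, on these numbers compound 1 stands highest, well apart from the other two, so it is the weakest binder of the three; compounds 2 and 3 share a carboxylic acid and a different sulfonamide portion, and no measured pair isolates any single change among them.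

Compound 4 `Cc1c(C(=O)NCCCN2CCN(C)CC2)c(-c2cccc(N3CCN(c4ccc(NS(=O)(=O)c5cccc(S(=O)(=O)C6CC6)c5)cc4)CC3)c2)c(-c2ccc(Cl)cc2)n1C` has not yet been measured. It differs from compound 1 in one place: cyclopropylsulfonyl in place of ethoxy on an aromatic carbon. Within the data shown here, no measured pair shows what this exchange alone does, so there is little to lean on. The step from compound 1 to compound 4 in this assay is expected to be modest, a 1.7-fold lower number from compound 1 to compound 4 (0.23 log units; within the scatter), leaning toward a lower number. Compound 4 is therefore expected to give about 250 nM in this assay, within a range from 60 nM to 1000 nM.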

Compound 4, inhibition constant: 218 nM
For compound 4 the middle estimate is 1.1-fold (0.06 log units) above the measured one; low and high end bracket the measured number.
By their numbers in this assay, from the lowest: compound 2; then compound 3; then compounds 4 and 1 (each within the scatter of the next).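

In this assay, placing cyclopropylsulfonyl where ethoxy stood on this aromatic carbon gives a 1.9-fold lower number from compound 1 to compound 4 (0.28 log units; within the scatter), so compounds 1 and 4 cannot be told apart. Within the data shown here, this is the first direct view of the position: it accepts a group with more heavy atoms, a three-membered ring and an extra hydrogen-bond acceptor with no change that can be read beyond the scatter. Nothing shown here offers an explanation for this result.

On these data alone, whether an amine, a carboxylic acid or a longer alkyl chain at this aromatic carbon would shift the number beyond the scatter remains open. So does whether the same exchange would read the same way on the core of compound 2, which carries a carboxylic acid.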